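Biaryl terminus: fluorines to tert-butyl on the shared core

The compounds below may be only part of what the source reports. "The series", "measured", "known", "first", "only" and "open" are said of these compounds alone.

Measured compounds:
- compound 1 `COC(=O)/C=C/c1cccc(N(Cc2ccc(/C=C/c3cccc(C(F)(F)F)c3)cc2)C(=O)NC(C)C)c1` — 932 nM
- compound 2 `COC(=O)/C=C/c1cccc(N(Cc2ccc(/C=C/c3ccccc3F)cc2)C(=O)NC(C)C)c1` — 431 nM
- compound 3 `COC(=O)/C=C/c1cccc(N(Cc2ccc(-c3ccc(F)c(F)c3)cc2)C(=O)C2CCCCC2)c1` — 72 nM

In an assay on isolated protein with Bile acid receptor (Homo sapiens) as the target (a higher number here means that more compound is needed for the effect, a lower number that less compound is needed), compound 3 gives the lowest number of the three; compound 2 sits next to it with 431 nM and compound 1 furthest with 932 nM, both gaps beyond the scatter. Compound 4 `COC(=O)/C=C/c1cccc(N(Cc2ccc(-c3ccc(C(C)(C)C)cc3)cc2)C(=O)C2CCCCC2)c1` is not yet measured. It differs from compound 3 in one place: 4-(tert-butyl)phenyl in place of 3,4-difluorophenyl on an aromatic carbon.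

Within the data shown here, only one step is available for comparison, a 2.2-fold lower number from compound 1 to compound 2 (0.33 log units; beyond the scatter), where a different aryl group on the double-bonded chain was exchanged; it was modest. Among the measured compounds shown here, no measured pair exchanges fluorines for a tert-butyl group on the biaryl terminus, so that step is only a loose guide. A modest step in this assay is therefore expected, more likely toward a higher number than a lower one, and it may well stay within the scatter. Compound 4 is estimated at 150 nM (range 50 nM to 450 nM), which corresponds to an expected step of a 2.1-fold higher number from compound 3 to compound 4 (0.32 log units; beyond the scatter).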

Compound 4, half-maximal effective concentration: 132 nM
Beside the measured number, compound 4's estimate is 1.1-fold (0.06 log units) above it; measured number inside the range.
By their numbers in this assay, from the lowest: compounds 3 and 4 (each within the scatter of the next); then compound 2; then compound 1.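

In this assay, the exchange of 3,4-difluorophenyl for 4-(tert-butyl)phenyl on an aromatic carbon gives a 1.8-fold higher number from compound 3 to compound 4 (0.26 log units; within the scatter), so the two termini cannot be told apart in this assay. Unlike the earlier step, a 2.2-fold lower number from compound 1 to compound 2 (0.33 log units; beyond the scatter), which concerned an aryl group on a double-bonded chain carbon, this one shows that, on the shared core with the cyclohexyl carbonyl, the fluorine atoms can give way to an all-carbon terminus of 10 heavy atoms rather than 8 without a change beyond the scatter. Nothing available explains why the two termini give values within the scatter of each other.

Still open, from the compounds shown here alone, is whether a terminal ring carrying an amine or a carboxylic acid would stay in this range. Also open, going by these compounds, is whether a 4-(tert-butyl)phenyl group would behave the same way on the double-bonded chain.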